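The source may hold more compounds than are shown below. What is called first, only, known or untested is meant among the compounds shown, and "the series" means these compounds.

Working notes on the cytotoxicity readings of this series.

Compound 1 `CC(C)COc1cccc(-c2ccc(C(=O)N(Cc3cccc(OCCCCCC(=O)O)c3)C(C)C)cc2)c1` in an ADME assay on BJ cells (Homo sapiens) for cytotoxicity, read by CellTiter-Glo and resazurin assay, with a stated time of 72 h (a lower number here means that less compound is needed, a higher number that more compound is needed for the effect), gives > 26000 nM, which is a limit of the assay and not a number. Compound 2 `CC(C)N(Cc1cccc(OCCCCCC(=O)O)c1)C(=O)c1ccc(-c2ccoc2)cc1` in this assay likewise gives > 26000 nM, again a limit rather than a measured value. On the numbers shown, compound 2 therefore stands nowhere definite: both values sit at the limit of > 26000 nM in this assay, at which 2 of the 2 values shown sit, and the step that the two limits leave unreadable from compound 1 to compound 2 is unreadable in size and direction.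

Compound 3 `CC(C)Oc1cccc(-c2ccc(C(=O)N(Cc3cccc(OCCCCCC(=O)O)c3)C(C)C)cc2)c1` has not yet been measured in this assay. The change is 3-isopropoxyphenyl in place of furan-3-yl on an aromatic carbon, and the 3-isopropoxyphenyl group entering differs from the 3-(isobutoxy)phenyl of compound 1 only in the alkoxy chain. For the measured compounds named here, the one measured step bearing on this position is a step that the two limits leave unreadable from compound 1 to compound 2, and it is unreadable, so no size of step beyond the scatter can be predicted in this assay. Given that compound 1 gives > 26000 nM as a limit, compound 3 is expected to fall similarly, with an expected step that the limit leaves unreadable from compound 2 to compound 3. The estimate for compound 3 in this assay is 30000 nM, ranging from 10000 nM to 100000 nM, most likely reported again only as a limit.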

Compound 3, half-maximal effective concentration: > 26000 nM
Compound 3 ended at the assay's limit; the forecaster's own chance of this, stated with the estimate: 75%; the middle value is on the limit's open side.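

No new step can be read among compound 1, compound 2 and compound 3 in this assay, as all three values are limits and not numbers: the limit of > 26000 nM in this assay, at which 3 of the 3 values shown sit.

The compounds shown leave open whether either change, at the aromatic carbon or in the alkoxy chain, alters the concentration needed for the effect in this assay at all.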